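Lengthening the Chain on Compound 2 by One Carbon

This account rests on a few compounds, and the source may have more. Where it says the series, first, only, none or still open, it means among the compounds named here.

Of the compounds shown here, three have been measured in a functional assay on HEK293 cells for agonist activity at G-protein coupled receptor 84 (Homo sapiens), read by calcium flux; on this read-out higher numbers stand for larger maximal responses and lower numbers for smaller maximal responses. Compound 1, with the structure `CCCCCCCc1cc(O)cc(O)n1`, reaches 87.8%. Compound 2, with the structure `CCCCCCCc1nc(O)cc(O)n1`, reaches 103%, and compound 3, with the structure `CCCCCCCCNc1nc(O)cc(O)n1`, reaches 91.8%. On these numbers compound 2 stands highest: compound 3 lies nearest to it, and the gap between them is beyond the scatter, while compound 1 lies furthest, also beyond the scatter. Within the data shown here, the compounds differ from one another in more than one place, so no single step between them can be followed.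

Compound 4, with the structure `CCCCCCCCc1nc(O)cc(O)n1`, has not yet been measured in this assay. It differs from compound 2 by methyl in place of hydrogen on a saturated chain carbon, seven bonds along the chain from an aromatic carbon. Since compound 2 already gives a response at about the level of the reference, only a small change is expected, none beyond the scatter, with the estimated step of a number 3 percentage points lower from compound 2 to compound 4 (within the scatter). For compound 4 the expected value in this assay is 100%, with a range from 85% to 115%.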

Compound 4, largest response reached (reported as percent of maximum), in percent of the reference or control that the assay uses: 110%
For compound 4 the middle estimate is 10 percentage points below the measured one; the range from low to high includes it.
By their numbers in this assay, from the lowest: compounds 1 and 3 (each within the scatter of the next); then compounds 2 and 4 (each within the scatter of the next).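

In this assay the step of a number 7 percentage points higher from compound 2 to compound 4 (within the scatter) comes from methyl in place of hydrogen on a saturated chain carbon, seven bonds along the chain from an aromatic carbon. Among these compounds, this is the first comparison here in which only one place differs, and it shows that this position accepts one more carbon while the maximal responses of compound 2 and compound 4 cannot be told apart. No supporting measurement bears on why the response stays at this level.

From the compounds shown here alone, whether a longer chain, or an amine or a carboxylic acid in place of this methyl, would also leave the maximal response within the scatter remains open. Going by these compounds, a maximal response also says nothing about the concentration needed to reach it, so any difference of that kind between these two compounds stays unknown.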